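The source may report more compounds than this note shows. Statements on the series, on what has been measured and on what is new or still open speak of the compounds shown alone.

Compound 1 `O=c1c(O)c(-c2ccccc2)oc2cc(OCc3ccccc3Cl)cc(O)c12` gives > 100000 nM in an ADME assay on Huh-5-2 cells (Homo sapiens) for cytotoxicity, read by WST assay, with a stated time of 3 days; on this read-out lower numbers stand for higher toxicity in this test and higher numbers for lower toxicity in this test. Compound 2 `O=c1c(O)c(-c2ccccc2)oc2cc(OCc3ccccc3Br)cc(O)c12` gives > 100000 nM in this assay. Compound 3 `O=c1c(O)c(-c2ccccc2)oc2cc(OCc3ccc(Cl)cc3)cc(O)c12` gives > 100000 nM in this assay.

Each of these three values is a limit of this assay rather than a number, a point where all three values sit together (the limit of > 100000 nM in this assay, at which 3 of the 3 values shown sit). Compound 1 and compound 2 differ by bromo in place of chloro on an aromatic carbon, and the step that the two limits leave unreadable from compound 1 to compound 2 stays unreadable because both ends are limits. Compound 1 and compound 3 share the same atoms joined differently, the difference being (4-chlorophenyl in place of 2-chlorophenyl on a saturated chain carbon bound to an oxygen on an aromatic ring), and again the step that the two limits leave unreadable from compound 1 to compound 3 cannot be read. Likewise the step that the two limits leave unreadable from compound 2 to compound 3 is hidden between two limits.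

Compound 4 `O=c1c(O)c(-c2ccccc2)oc2cc(OCc3ccc(Br)cc3)cc(O)c12` has not yet been tested in this assay. It differs from compound 3 by bromo in place of chloro on an aromatic carbon. This is the same kind of change as that from compound 1 to compound 2, but the place differs: ortho to a large group in compound 2, para to a large group in compound 4.

Compound 4 is expected to show a step that the limit leaves unreadable from compound 3 to compound 4 from compound 3, an expectation resting on compound 3 giving > 100000 nM and on every value sitting at the limit (the limit of > 100000 nM in this assay, at which 3 of the 3 values shown sit). The estimate for compound 4 is 150000 nM, expected between 60000 nM and 500000 nM.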

Compound 4, half-maximal cytotoxic concentration: > 100000 nM
Compound 4: no number, only a limit (the forecaster's own chance of this, stated with the estimate: 85%); the middle value does not contradict the limit.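

The steps from compound 1, compound 2 and compound 3 to compound 4 cannot be read in this assay because both ends of each step are limits and not numbers: the limit of > 100000 nM in this assay, at which 4 of the 4 values shown sit.

Left open is how toxic any of these four compounds is in this assay and whether chloro or bromo, or the place of either, makes any difference there.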